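The source may hold more compounds than are shown below. What is called first, only, known or untested is meant among the compounds shown, and "the series" means these compounds.

Working notes on the series. In a functional assay on A-375 cells (Homo sapiens) for cytotoxicity, read by MTT assay (a higher number here means a weaker inhibitor, a lower number a stronger inhibitor), compound 1 (`COc1ccc(/C=C/C(=O)c2ccc(OC)c3c2OC(C)(C)C=C3)cc1OCC=C(C)C`) gives > 10000 nM as a limit and not a number. Compound 2 (`C#CCOc1cc(/C=C/C(=O)c2ccc(OC)c3c2OC(C)(C)C=C3)ccc1OC`) gives > 10000 nM as a limit too. Compound 3 (`C=CCOc1cc(/C=C/C(=O)c2ccc(OC)c3c2OC(C)(C)C=C3)ccc1OC`) gives > 10000 nM as a limit as well. Compound 3 therefore stands with the other two at the limit of > 10000 nM in this assay, at which 3 of the 3 values shown sit, and has no measured number.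

Compound 4 (`COc1ccc(/C=C/C(=O)c2ccc(OC)c3c2OC(C)(C)C=C3)cc1OC(=O)C(C)C`) carries isopropylcarbonyl in place of the allyl of compound 3 on an oxygen on an aromatic ring: isopropylcarbonyl in place of allyl on an oxygen on an aromatic ring turns allyloxy into (isopropylcarbonyl)oxy.

The nearest evidence comes from changes to the same chain: a step that the two limits leave unreadable from compound 1 to compound 3 and a step that the two limits leave unreadable from compound 2 to compound 3 along with a step that the two limits leave unreadable from compound 1 to compound 2 are all without a readable size. None of them introduces a carbonyl, so they give only weak guidance.

No change beyond the usual scatter is expected in this assay and the estimated step is a step that the limit leaves unreadable from compound 3 to compound 4 with no direction favoured. Compound 4 is expected at about 12000 nM within an estimated range of 4000 nM to 30000 nM and may well turn out to be only a limit.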

Compound 4, half-maximal inhibitory concentration: 310 nM
The estimate for compound 4 lay 39-fold (1.59 log units) above the measured number; measured number below the stated range.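

In this assay this position on the oxygen on an aromatic ring proves able to carry a readable change, with an at least 32-fold lower number from compound 3 to compound 4 (1.50 log units; beyond the scatter), together with an at least 32-fold lower number from compound 2 to compound 4 (1.50 log units; beyond the scatter) and an at least 32-fold lower number from compound 1 to compound 4 (1.50 log units; beyond the scatter). The steps among compounds 1, 2 and 3 cannot be read, whereas replacing any of their allyl, propargyl or 3-methylbut-2-en-1-yl groups with isopropylcarbonyl gives a measured number, and this is the only group shown here that brings a carbonyl to the position. Compounds 1, 2 and 3 all remain at a limit and not a number: the limit of > 10000 nM in this assay, at which 3 of the 4 values shown sit.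

On these data alone, the true size of these steps stays open, and the printed sizes are lower bounds only. Also open, as far as these compounds go, is whether the carbonyl or the isopropyl part carries the change, which an acetyl, a longer acyl chain or a free hydroxyl on the same oxygen would help to separate.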